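This account rests on a few compounds, and the source may have more. Where it says the series, first, only, none or still open, it means among the compounds named here.

Working notes on the dog exposure series.

Compound 1 `CCOC(=O)C1=C(S[C@@H]2CN[C@H](C(=O)Nc3cccc(C(=O)OCC)c3)C2)[C@H](C)[C@@H]2[C@@H]([C@@H](C)O)C(=O)N12` carries the shared core with two ethyl esters. Going by the values given here, in an ADME assay on the whole organism (plasma, strain Beagle) for pharmacokinetics, with Canis familiaris (Canis lupus familiaris) as the target, read by LC-MS, with a stated time of 8 h, at a dose of 10 mg/kg by the intraduodenal route (on this read-out higher numbers stand for higher exposure at the dose given and lower numbers for lower exposure), compound 1 gives 7600 ng.h/mL, the highest of the three numbers so far, though its gaps to the other two lie within the scatter. Compound 2 `CCCOC(=O)C1=C(S[C@@H]2CN[C@H](C(=O)Nc3cccc(C(=O)OCCC)c3)C2)[C@H](C)[C@@H]2[C@@H]([C@@H](C)O)C(=O)N12` gives 4090 ng.h/mL in this assay, and compound 3 `C[C@@H](O)[C@H]1C(=O)N2C(C(=O)OCC(F)(F)F)=C(S[C@@H]3CN[C@H](C(=O)Nc4cccc(C(=O)OCC(F)(F)F)c4)C3)[C@H](C)[C@H]12` gives 4290 ng.h/mL. Among the compounds with values here, no pair differs in only one place, so no single step can be read from them.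

Compound 4 `CCOC(=O)C1=C(S[C@@H]2CN[C@H](C(=O)Nc3cccc(C(=O)OCC)c3)C2)[C@H](C)[C@@H]2[C@@H]([C@@H](C)OC(C)=O)C(=O)N12` differs from compound 1 as follows: acetyl in place of hydrogen on an oxygen on a saturated carbon. Within the data shown here, the three compounds show no measured step for such a change, and the values so far spread little. The step from compound 1 to compound 4 is expected to be a 1.1-fold lower number from compound 1 to compound 4 (0.04 log units; within the scatter), not beyond the scatter. Compound 4 is expected to give 7000 ng.h/mL, range 2500 ng.h/mL to 20000 ng.h/mL.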

Compound 4, area under the concentration-time curve: 6480 ng.h/mL
Compound 4: middle estimate off by 1.1-fold (0.03 log units), on the high side; the range from low to high includes it.
By their numbers in this assay, from the lowest: compounds 2, 3, 4 and 1 (each within the scatter of the next).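

In this assay, going by these compounds alone, hydroxy to acetoxy on the 1-hydroxyethyl group gives a 1.2-fold lower number from compound 1 to compound 4 (0.07 log units; within the scatter), the first measured step at this position. With the two ethyl esters held fixed, acetyl on this oxygen leaves the number within the scatter, so exposure here does not depend on a free hydroxy. No measurement on hand shows why the number holds. Open, on these data alone, is whether a longer acyl chain such as butanoyl, or an amine-bearing acyl such as glycyl, on this oxygen would do the same. Also open, as far as these compounds go, is whether the acetyl change would hold with the propyl esters of compound 2 or the trifluoroethyl esters of compound 3.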